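Chloro on the shared core: compounds 1 to 4

A few compounds are considered here, and "the series" means these few. Any claim that something is new, unique, unknown or untested is made for them only; others in the source may bear on it.

Measured in a functional assay on CCRF-CEM cells (Homo sapiens) for antiproliferative activity, with a stated time of 72 h; a higher number here means a weaker inhibitor, a lower number a stronger inhibitor:
compound 1 `COc1ccc(-n2c(-c3cc(OC)c(OC)c(OC)c3)csc2=O)cc1[N+](=O)[O-]` — 2700 nM
compound 2 `COc1ccc(-n2c(-c3cc(OC)c(OC)c(OC)c3)c(Cl)sc2=O)cc1[N+](=O)[O-]` — > 20000 nM, a limit of the assay
compound 3 `COc1ccc(-c2csc(=O)n2-c2cc(OC)c(OC)c(OC)c2)cc1[N+](=O)[O-]` — 8200 nM

Compound 1 is the reference; in this assay compound 1 gives 2700 nM. Compound 2 differs from it by chloro in place of hydrogen on an aromatic carbon. For compound 2 only a limit is reported, > 20000 nM. The step of an at least 7.4-fold higher number from compound 1 to compound 2 (0.86 log units; beyond the scatter) therefore runs into the limit of > 20000 nM in this assay, at which 1 of the 3 values shown sits, and its full size is not known.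

Compound 3 has the same atoms as compound 1, joined differently; the difference between the two cores is not broken down here. In this assay compound 3 gives 8200 nM, a higher number than compound 1 and beyond the scatter.

Compound 4 `COc1ccc(-c2c(Cl)sc(=O)n2-c2cc(OC)c(OC)c(OC)c2)cc1[N+](=O)[O-]` has not been measured. It differs from compound 3 by chloro in place of hydrogen on an aromatic carbon, the same change as from compound 1 to compound 2, at the same place. The step is expected to be a 5.5-fold higher number from compound 3 to compound 4 (0.74 log units; beyond the scatter), resting on the measured step of an at least 7.4-fold higher number from compound 1 to compound 2 (0.86 log units; beyond the scatter). The estimate for compound 4 in this assay is 45000 nM, between 15000 nM and 150000 nM. Because the start point is already weaker and the earlier step reached (the limit of > 20000 nM in this assay, at which 1 of the 3 values shown sits), compound 4 is expected to return only a limit rather than a number.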

Compound 4, half-maximal inhibitory concentration: 7500 nM
The estimate for compound 4 lay 6.0-fold (0.78 log units) above the measured number; measured number below the stated range.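

In this assay, chloro in place of hydrogen on an aromatic carbon gives a 1.1-fold lower number from compound 3 to compound 4 (0.04 log units; within the scatter), so on the core of compound 3 the change leaves no readable effect on antiproliferative activity. The change therefore cannot be carried from the core of compound 1 to the core of compound 3 with its size intact, and the earlier step is no guide to this one: the same change on two cores in this assay, an at least 7.4-fold higher number (0.86 log units; beyond the scatter) from compound 1 to compound 2 and a 1.1-fold lower number (0.04 log units; within the scatter) from compound 3 to compound 4, at least 8.0-fold (0.90 log units) apart, beyond the scatter of two such steps

What this does not show is any reason for the gap between the two cores or the full size of the step on the core of compound 1, where compound 2 gives only a limit of the assay: the limit of > 20000 nM in this assay, at which 1 of the 4 values shown sits.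

The compounds shown leave open whether a methyl group or an amine on the aromatic carbon next to the ring sulfur would also separate the two cores. Also open, going by these compounds, is whether fluoro or bromo at that carbon would follow chloro on either core.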